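Compound 2 and the move to a trifluoromethyl carbonyl

The compounds below may be only part of what the source reports. "The series", "measured", "known", "first", "only" and "open" are said of these compounds alone.

Compound 1 `Cc1ccc(-c2noc(CCCCCCC(=O)NO)n2)cc1` gives 15800 nM here
Compound 2 `Cc1ccc(-c2noc(CCCCCCC(=O)Nc3ccccc3N)n2)cc1` gives 410 nM here
Compound 3 `Nc1ccccc1NC(=O)CCCCCCc1nc(-c2ccc(C(F)(F)F)cc2)no1` gives 29800 nM here

Compound 2 holds the lowest number of the three measured in a functional assay on NCI-H661 cells (Homo sapiens) for antiproliferative activity, read by MTT assay, with a stated time of 72 h (on this read-out higher numbers stand for weaker inhibition and lower numbers for stronger inhibition), and so shows the strongest inhibition of them. Compound 4 `Cc1ccc(-c2noc(CCCCCCC(=O)C(F)(F)F)n2)cc1` differs from it by one change: trifluoromethyl in place of (2-aminophenyl)amino on a carbonyl carbon in a single swap. The measured step closest to this change also involves the 2-aminophenyl group, since 2-aminophenyl in place of hydroxy on an amide-type nitrogen gave a 39-fold lower number from compound 1 to compound 2 (1.59 log units; beyond the scatter) as a large step. The other measured change gave a 73-fold higher number from compound 2 to compound 3 (1.86 log units; beyond the scatter) on an aromatic carbon, not on the carbonyl carbon, so it bears only indirectly. Compound 4 has no 2-aminophenyl group, so going by a 39-fold lower number from compound 1 to compound 2 (1.59 log units; beyond the scatter) in reverse, a large step to a higher number is expected in this assay for it. Among the measured compounds shown here, no measured compound carries trifluoromethyl on the carbonyl carbon, so this remains uncertain. The expected size is a 29-fold higher number from compound 2 to compound 4 (1.47 log units; beyond the scatter) as estimated here. The estimated value for compound 4 is 12000 nM with an expected range from 2500 nM to 50000 nM on this read-out.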

Compound 4, half-maximal inhibitory concentration: 18700 nM
Estimate against measurement, compound 4: 1.6-fold (0.19 log units) below, within the range that was stated.
By their numbers in this assay, from the lowest: compound 2; then compounds 1, 4 and 3 (each within the scatter of the next).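

On the carbonyl carbon, trifluoromethyl in place of (2-aminophenyl)amino gave a 46-fold higher number from compound 2 to compound 4 (1.66 log units; beyond the scatter) in this assay and so did not keep the low number of compound 2. Trifluoromethyl and hydroxyamino at this place could not be told apart, with a 1.2-fold higher number from compound 1 to compound 4 (0.07 log units; within the scatter) on the same core. Of the three groups seen on this carbonyl carbon with the methyl-bearing core, only (2-aminophenyl)amino goes with a low number, and nothing given here offers a measured explanation for this.

As far as these compounds go, it remains open whether phenylamino, which lacks the amine of the 2-aminophenyl group, or a carboxylic acid at this carbonyl carbon would stand with compound 2 or with compound 1 and compound 4. Also open, from the compounds shown here alone, is whether the same contrast between these groups would hold on a longer chain.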